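From 3-bromophenyl to 4-bromophenyl in the series

The source may hold more compounds than are shown below. What is called first, only, known or untested is meant among the compounds shown, and "the series" means these compounds.

Among the measured compounds shown here, in an ADME assay on MDBK cells (Bos taurus) for cytotoxicity (on this read-out higher numbers stand for lower toxicity in this test and lower numbers for higher toxicity in this test), compound 3 `Brc1cccc(Cn2ccc3nc(-c4ccccc4)nc-3c2)c1` gives 85000 nM, the only actual number so far. Compound 1 `Cc1ccc(Cn2ccc3nc(-c4ccccc4)nc-3c2)cc1` gives > 100000 nM, which is a limit of the assay. Compound 2 `Fc1cccc(Cn2ccc3nc(-c4ccccc4)nc-3c2)c1` gives > 100000 nM, also a limit. Compound 4 `Brc1ccc(Cn2ccc3nc(-c4ccccc4)nc-3c2)cc1` follows from compound 3 by 4-bromophenyl in place of 3-bromophenyl on a saturated chain carbon bound to an aromatic nitrogen. For the measured compounds named here, three measured steps bear on this change: an at least 1.1-fold lower number from compound 1 to compound 3 (0.07 log units; that floor lies within the scatter) and an at least 1.1-fold lower number from compound 2 to compound 3 (0.07 log units; that floor lies within the scatter), both floors within the scatter, and a step that the two limits leave unreadable from compound 1 to compound 2. Compound 1 already carries a 4-methylphenyl, and its step to compound 3 gives no readable size. The expected result is a 1.1-fold higher number from compound 3 to compound 4 (0.02 log units; within the scatter), with no change expected beyond the scatter in either direction. Compound 4 is estimated at 90000 nM, with an expected range of 50000 nM to 120000 nM.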

Compound 4, half-maximal cytotoxic concentration: 83000 nM
Beside the measured number, compound 4's estimate is 1.1-fold (0.04 log units) above it, within the range that was stated.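

In this assay, among the compounds shown here, 4-bromophenyl in place of 3-bromophenyl gives a 1.0-fold lower number from compound 3 to compound 4 (0.01 log units; within the scatter), the only step here between two actual numbers, so this change at this place shows nothing beyond the scatter. The other two steps, an at least 1.2-fold lower number from compound 2 to compound 4 (0.08 log units; that floor lies within the scatter) and an at least 1.2-fold lower number from compound 1 to compound 4 (0.08 log units; that floor lies within the scatter), are floors within the scatter and show no readable difference. Both start from a limit of the assay: the limit of > 100000 nM in this assay, at which 2 of the 4 values shown sit.

Still open, as far as these compounds go, is whether an amine or a carboxylic acid in place of bromo on the phenyl ring would move the number beyond the scatter. From the compounds shown here alone, a longer chain in place of the saturated chain carbon also remains open.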